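Ring group exchange from compound 3 to compound 4

This account rests on a few compounds, and the source may have more. Where it says the series, first, only, none or still open, it means among the compounds named here.

In a physicochemical assay for lipophilicity, using the shake flask method, measured as octanol-water partition, at pH 7.4 (a lower number here means a more polar compound, a higher number a more lipophilic compound), compound 3 (`CC(C)n1cc(-c2ccnc3[nH]c(C4CCN(CC(=O)N(C)C)CC4)cc23)cnc1=O`) gives 0.4, above compound 1 (`CC(C)n1cc(-c2ccnc3[nH]c(C4CCNCC4)cc23)ccc1=O`) at -0.2, while compound 2 (`CNC(=O)CN1CCC(c2cc3c(-c4ccc(=O)n(C(C)C)c4)ccnc3[nH]2)CC1`) gives 2.2. Compound 4 (`CCn1cc(-c2ccnc3[nH]c(C4CCN(CC(=O)N(C)C)CC4)cc23)ccc1=O`) differs from compound 3 by a group of 9 heavy atoms (7 carbon, 1 nitrogen, 1 oxygen; one six-membered aromatic ring with 1 hetero atom) in place of a group of 10 heavy atoms (7 carbon, 2 nitrogen, 1 oxygen; one six-membered aromatic ring with 2 hetero atoms), on an aromatic carbon, on an aromatic carbon. Within the data shown here, the only measured step, a number 2.40 log units higher from compound 1 to compound 2 (beyond the scatter), lies at an amine nitrogen in a ring, not at this carbon, so it bears only indirectly, as a large step. Closer guidance is compound 2 at 2.2, which has a six-membered aromatic ring with 1 hetero atom at this carbon. A rise beyond the scatter is therefore expected, with a number 1.30 log units higher from compound 3 to compound 4 (beyond the scatter) estimated. For compound 4 the estimated value is 1.7, with an expected range of 1.1 to 2.2.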

Compound 4, distribution coefficient: 1.2
The estimate for compound 4 lay 0.50 log units above the measured number, and the stated range covers the measured number.
By their numbers in this assay, from the lowest: compound 1; then compound 3; then compound 4; then compound 2.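

In this assay, the exchange on this aromatic carbon gives a number 0.80 log units higher from compound 3 to compound 4 (beyond the scatter), so the number also moves at this carbon and not only at the amine nitrogen in a ring. This step is modest, whereas a number 2.40 log units higher from compound 1 to compound 2 (beyond the scatter) is large. No available data explain the change.

Going by these compounds, the two groups differ in more than the ring hetero atoms, so the share of the step belonging to those atoms stays open. Also open, on these data alone, is how the number would respond to an amine or a carboxylic acid on this aromatic carbon.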